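The source may hold more compounds than are shown below. What is called first, only, known or untested is meant among the compounds shown, and "the series" means these compounds.

Compound 2 `Cc1nc(C)n(CC(=O)N2CCN(c3sc(C(F)(F)F)nc3-c3cnc(OC(C)C)nc3)C[C@H]2C)n1` and compound 1 `CCOc1ncc(-c2nc(C(F)(F)F)sc2N2CCN(C(=O)Cn3ncc4cccnc43)[C@H](C)C2)cn1` share a core and are both strong inhibitors. In a functional assay on CHO-K1 cells for antagonist activity at C-X-C chemokine receptor type 3 (Homo sapiens), read by FLIPR, with a stated time of 10 min (on this read-out lower numbers stand for stronger inhibition and higher numbers for weaker inhibition), compound 2 gives 3.4 nM, and compound 1 gives 4.1 nM; the two values lie within the scatter of each other, so neither can be called more potent. Compound 3 `COc1ccc(-c2nc(C(F)(F)F)sc2N2CCN(C(=O)Cn3nc(C)nc3C)[C@H](C)C2)cn1` has not been measured. It differs from compound 2 by 6-methoxypyridin-3-yl in place of 2-isopropoxypyrimidin-5-yl on an aromatic carbon. For the measured compounds named here, no measured pair shows this change, so the expected step from compound 2 to compound 3 is small, at most a modest loss: a 1.8-fold higher number from compound 2 to compound 3 (0.25 log units; within the scatter). Compound 3 is therefore estimated to give 6 nM in this assay, between 2 nM and 20 nM.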

Compound 3, half-maximal inhibitory concentration: 18 nM
Compound 3: the middle estimate sits 3.0-fold (0.48 log units) below what was measured; low and high end bracket the measured number.
By their numbers in this assay, from the lowest: compounds 2 and 1 (each within the scatter of the next); then compound 3.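

In this assay, 6-methoxypyridin-3-yl in place of 2-isopropoxypyrimidin-5-yl gives a 5.3-fold higher number from compound 2 to compound 3 (0.72 log units; beyond the scatter), so this aromatic carbon, next to the ring nitrogen, does not treat the two groups alike. The change is modest in size but lies beyond the scatter, and it alters the ring and the group on oxygen together. Nothing measured here explains this loss.

Still open, on these data alone, is which of the two alterations carries the step. A 2-methoxypyrimidin-5-yl or a 6-isopropoxypyridin-3-yl group at this carbon would separate them.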